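Selenium alkyl swap on a bis-benzamide series

A few compounds are considered here, and "the series" means these few. Any claim that something is new, unique, unknown or untested is made for them only; others in the source may bear on it.

Measured compounds:
Compound 1 `C[Se]/C(=N\C(=O)c1ccccc1)NC(=O)c1ccccc1` — in a functional assay on PC-3 cells (Homo sapiens) for cytotoxicity, read by MTT assay (a higher number here means a weaker inhibitor, a lower number a stronger inhibitor), compound 1 gives 2500 nM.
Compound 2 `CC(C)[Se]/C(=N\C(=O)c1ccccc1)NC(=O)c1ccccc1` — in this assay compound 2 returns only a limit of the assay, > 10000 nM.
Compound 3 `C[Se]/C(=N\C(=O)c1ccc(Cl)cc1)NC(=O)c1ccc(Cl)cc1` — in this assay compound 3 gives 7600 nM.

Among the compounds with values here, the one change that is measured in this set is from compound 1 to compound 2: isopropyl in place of methyl on a selenium. It produced an at least 4.0-fold higher number from compound 1 to compound 2 (0.60 log units; beyond the scatter). The true size of that step is not known, since it runs into (the limit of > 10000 nM in this assay, at which 1 of the 3 values shown sits), and the value of compound 2 is a limit rather than a number.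

Compound 3 stands highest of the two numbers available. The difference between its core and the core of compound 1 is not broken down here.

Compound 4 `CC(C)[Se]/C(=N\C(=O)c1ccc(Cl)cc1)NC(=O)c1ccc(Cl)cc1` is not yet measured. Within the data shown here, it differs from compound 3 by isopropyl in place of methyl on a selenium, which is the same change as the one from compound 1 to compound 2, at the same place.

The expected step is a 3.9-fold higher number from compound 3 to compound 4 (0.60 log units; beyond the scatter), resting on the measured step of an at least 4.0-fold higher number from compound 1 to compound 2 (0.60 log units; beyond the scatter). Compound 3 already gives 7600 nM in this assay. Compound 4 is therefore expected near 30000 nM, in the range 12000 nM to 80000 nM, and the assay may well report only a limit for it rather than a number.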

Compound 4, half-maximal inhibitory concentration: > 10000 nM
Compound 4: no number, only a limit; the forecaster's own chance of this, stated with the estimate: 80%; the middle value does not contradict the limit.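

In this assay compound 4 returns only a limit of the assay, > 10000 nM. On the second core, isopropyl in place of methyl on a selenium gives an at least 1.3-fold higher number from compound 3 to compound 4 (0.11 log units; that floor lies within the scatter), which agrees in direction with the step on the first core but does not by itself show a loss beyond the scatter. The change can therefore be said not to contradict the earlier step on this second core, while any claim that it carries over with the same size is out of reach: the same change on two cores in this assay, an at least 4.0-fold higher number (0.60 log units; beyond the scatter) from compound 1 to compound 2 and an at least 1.3-fold higher number (0.11 log units; that floor lies within the scatter) from compound 3 to compound 4; the limit leaves it open whether they differ.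

On these data alone, neither isopropyl compound gives a number, so the real size of the loss on either core stays unknown: the limit of > 10000 nM in this assay, at which 2 of the 4 values shown sit. Also open, as far as these compounds go, are the effects of other groups on the selenium, such as ethyl, a longer chain or a chain ending in an amine, and whether a core with fluorine or methoxy in place of chlorine would give values nearer to compound 1 or to compound 3.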